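Oxamide series on the shared core: ester to free acid

The source may hold more compounds than are shown below. What is called first, only, known or untested is meant among the compounds shown, and "the series" means these compounds.

Measured compounds:
compound 1, `O=C(O)C(=O)Nc1cccccc1=O` — 89%; 70% (2 entries)
compound 2, `CCOC(=O)COC(=O)C(=O)Nc1cccccc1=O` — 69%

In a functional assay on the whole organism (strain Sprague-Dawley CD) for inhibition, with Rattus norvegicus as the target, read by paw edema, at a dose of 10 mg/kg by the intraperitoneal route (on this read-out lower numbers stand for a weaker effect and higher numbers for a stronger effect at the one dose given), compound 1 gives 89%; 70% (2 entries); its two repeats, (the several entries of compound 1 in this assay, 89%; 70% (2 entries)), show how far duplicate runs of this kind can lie apart. Among the measured compounds shown here, compound 2 gives 69%, the single value available for it; one further entry carries no number at all. Its value sits within the span covered by the two entries of compound 1, so the two compounds cannot be set in any order against each other.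

Compound 3, `O=C(O)COC(=O)C(=O)Nc1cccccc1=O`, is still to be measured in this assay. It differs from compound 2 by hydrogen in place of ethyl on an oxygen next to a carbonyl group. For the measured compounds named here, no measured pair contains the same change, so no step size can be read off from the data. The expectation in this assay is a step no larger than the usual scatter, with no settled direction; compound 1, which also carries a carboxy group, falls in the same region as compound 2. The step expected from compound 2 to compound 3 is a number 3 percentage points higher from compound 2 to compound 3 (within the scatter). Compound 3 is estimated at 72%, with a range from 55% to 88%.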

Compound 3, a percentage reported as inhibition, in the whole organism at one dose (the size of the read-out at that dose, not a potency): 66%
Compound 3: middle estimate off by 6 percentage points, on the high side; the measured number falls inside the stated range.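

Oxygen position of the ester end: the first step that can be read here is the exchange of ethyl for hydrogen on an oxygen next to a carbonyl group, and in this assay it gives a number 3 percentage points lower from compound 2 to compound 3 (within the scatter). The read-out therefore does not separate the ethoxycarbonyl end from the carboxy end on this chain: at this position, the ethyl group is not needed to keep the effect seen in the ester, and the free acid is not set apart from it in either direction. The read-out gives the size of the effect at one dose and not a potency, and a step of this size has to be weighed against how far repeat entries can lie apart: the several entries of compound 1 in this assay, 89%; 70% (2 entries)

Still open, going by these compounds, is whether a group of another kind on this oxygen, such as a longer chain like butyl, a benzyl group, or an amide with an amine in place of the ester oxygen, would move the read-out beyond the scatter. Also open, on these data alone, is whether the absence of a clear step between ester and acid would hold at other doses.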